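The source may report more compounds than this note shows. Statements on the series, on what has been measured and on what is new or still open speak of the compounds shown alone.

Working notes on the series. Two members have so far been tested for cytotoxicity in an ADME assay on CRL8155 cells (Homo sapiens) for cytotoxicity, read by resazurin assay, with a stated time of 72 h; on this read-out higher numbers stand for an effect only at larger amounts of compound and lower numbers for an effect already at smaller amounts. Compound 1 `O=C(NCCC1CCNCC1)Nc1nc2ccc(C(=O)c3ccccc3)cc2[nH]1` gives only a limit in this assay, > 30000 nM, and no number. Compound 2 `CN1CCC(Cn2c(N)nc3ccc(C(=O)c4ccccc4)cc32)CC1` likewise gives only a limit, > 30000 nM. Going by the values given here, compound 2 therefore stands where every value so far stands, at the limit of > 30000 nM in this assay, at which 2 of the 2 values shown sit, and since no member yet yields a number, no step between measured compounds can be drawn. Compound 3 `Nc1nc2ccc(C(=O)c3ccccc3)cc2n1C[C@H]1CCCN1` is the next member to be measured, and it differs from compound 2 by pyrrolidin-2-yl in place of 1-methylpiperidin-4-yl on a saturated chain carbon bound to an aromatic nitrogen. With compound 2 resting at the limit of > 30000 nM in this assay, at which 2 of the 2 values shown sit, a step toward compound 3 could only become visible if compound 3 dropped under the limit. No step beyond the scatter is expected: a number no higher from compound 2 to compound 3 (the limit leaves the size open). Compound 3 is accordingly expected to give 30000 nM, most plausibly again as a limit, within a range from 12000 nM to 100000 nM.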

Compound 3, half-maximal effective concentration: > 30000 nM
Compound 3: a limit, no number; the forecaster's own chance of this, stated with the estimate: 80%; the middle value lies on the limit itself.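

In this assay no new step can be read from compound 2 to compound 3, as both give only a limit: the limit of > 30000 nM in this assay, at which 3 of the 3 values shown sit.

Left open is whether pyrrolidin-2-yl in place of 1-methylpiperidin-4-yl changes the read-out at all, as none of the compounds shown yields a number.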